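Swapping 4-nitrophenyl for 2-chloro-4-fluorophenyl in compound 3

The source may report more compounds than this note shows. Statements on the series, on what has been measured and on what is new or still open speak of the compounds shown alone.

Compound 1 `COc1cc2ncnc(Nc3ccc(F)c(Cl)c3)c2cc1NC(=O)N/N=C/c1ccc(F)cc1` gives 31100 nM
Compound 2 `COc1cc2ncnc(Nc3ccc(F)c(Cl)c3)c2cc1NC(=O)N/N=C/c1cccc(Br)c1` gives "not active" (no number reported)
Compound 3 `COc1cc2ncnc(Nc3ccc(F)c(Cl)c3)c2cc1NC(=O)N/N=C/c1ccc([N+](=O)[O-])cc1` gives 34100 nM

For the measured compounds named here, in a functional assay on HepG2 cells (Homo sapiens) for cytotoxicity, read by MTT assay, with a stated time of 72 h (on this read-out higher numbers stand for weaker inhibition and lower numbers for stronger inhibition), compound 3 gives 34100 nM and stands level, within the scatter, with compound 1, the only other number. Compound 4 `COc1cc2ncnc(Nc3ccc(F)c(Cl)c3)c2cc1NC(=O)N/N=C/c1ccc(F)cc1Cl` arises through 2-chloro-4-fluorophenyl in place of 4-nitrophenyl on a carbon with a double bond to nitrogen in which 2-chloro-4-fluorophenyl replaces 4-nitrophenyl on a carbon with a double bond to nitrogen. Going by the values given here, the only measured step is a 1.1-fold higher number from compound 1 to compound 3 (0.04 log units; within the scatter) and it stays within the scatter, so it offers no ground for a large move. Compound 2 at "not active" (no number reported) leaves some chance that no number comes back. The expected size is a 1.1-fold lower number from compound 3 to compound 4 (0.06 log units; within the scatter) and thus no step beyond the scatter. Compound 4 is estimated at 30000 nM within a range from 15000 nM to 60000 nM by this expectation.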

Compound 4, half-maximal inhibitory concentration: 29200 nM
Beside the measured number, compound 4's estimate is 1.0-fold (0.01 log units) above it, within the range that was stated.
By their numbers in this assay, from the lowest: compounds 4, 1 and 3 (each within the scatter of the next).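

In this assay, 2-chloro-4-fluorophenyl in place of 4-nitrophenyl on a carbon with a double bond to nitrogen gives a 1.2-fold lower number from compound 3 to compound 4 (0.07 log units; within the scatter) for a group with no nitro, and chloro in place of hydrogen on an aromatic carbon gives a 1.1-fold lower number from compound 1 to compound 4 (0.03 log units; within the scatter) as a second step of the same kind. This place therefore carries three differently substituted phenyl groups with numbers level within the scatter. No measurement shown here offers a cause for this.

What the compounds shown leave open is whether a group without a phenyl ring at this place, such as an amine, a carboxylic acid or a longer chain, would move the number beyond the scatter.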